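A few compounds are considered here, and "the series" means these few. Any claim that something is new, unique, unknown or untested is made for them only; others in the source may bear on it.

Measured compounds:
- compound 1, `CC(C)c1onc(-c2c(Cl)cccc2Cl)c1COc1ccc(-c2nc3ccc(C(=O)O)cc3n2CC2CC2)cc1`, 19.4 nM
- compound 2, `CCC(CC)n1c(-c2ccc(OCc3c(-c4c(Cl)cccc4Cl)noc3C(C)C)cc2Cl)nc2ccc(C(=O)O)cc21`, 1.6 nM
- compound 3, `CC(C)c1onc(-c2c(Cl)cccc2Cl)c1COc1ccc(-c2nc3ccc(C(=O)O)cc3n2C)cc1Cl`, 19 nM

All three were read in an assay on Huh-7 cells for agonist activity at Bile acid receptor (Homo sapiens), read by a luciferase reporter; on this read-out lower numbers stand for an effect already at smaller amounts and higher numbers for an effect only at larger amounts of compound. Compound 1 has the highest number of the three in this assay, at 19.4 nM. Its nearest neighbour is compound 3 at 19 nM, a gap that lies within the scatter, so no order between compound 1 and compound 3 can be stated. Among the compounds with values here, compound 2 at 1.6 nM stands well apart, beyond the scatter; it differs from compound 1 in more than one place, so no single-point step can be drawn from it.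

Compound 4, `CC(C)Cn1c(-c2ccc(OCc3c(-c4c(Cl)cccc4Cl)noc3C(C)C)cc2)nc2ccc(C(=O)O)cc21`, has not yet been measured. It differs from compound 1 in one place: isopropyl in place of cyclopropyl on a saturated chain carbon bound to an aromatic nitrogen. Within the data shown here, no measured pair shows this change on its own, so its effect here is unknown. A step of this kind, swapping one three-carbon group for another on the same saturated chain carbon, is expected to be small, most likely within the scatter and, if anything, toward a slightly lower number. The number for compound 4 in this assay is estimated at 13 nM, with a likely range from 4 nM to 40 nM, which means an expected step of a 1.5-fold lower number from compound 1 to compound 4 (0.17 log units; within the scatter).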

Compound 4, half-maximal effective concentration: 5.26 nM
Compound 4: the middle estimate sits 2.5-fold (0.39 log units) above what was measured, and the stated range covers the measured number.
By their numbers in this assay, from the lowest: compound 2; then compound 4; then compounds 3 and 1 (each within the scatter of the next).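

Within the data shown here, this is the first single-point step at this position: in this assay, isopropyl in place of cyclopropyl on a saturated chain carbon bound to an aromatic nitrogen gives a 3.7-fold lower number from compound 1 to compound 4 (0.57 log units; beyond the scatter). Both groups carry 3 heavy atoms, all carbon, and neither has hydrogen-bond donors or acceptors, so the read-out here responds to a change that removes the three-membered ring without altering those counts. Nothing measured here accounts for the size or direction of this step.

This single pair leaves open whether the same swap gives a similar step elsewhere in the series. Also open, from the compounds shown here alone, is how a cyclobutyl ring or a hydroxyl group in this place would read in this assay.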